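The compounds below may be only part of what the source reports. "The series", "measured", "known", "first", "only" and "open" are said of these compounds alone.

Working notes on the series. In an in vitro functional assay on cells for agonist activity at Bombesin receptor subtype-3 (Homo sapiens), read by luminescence and calcium flux (on this read-out higher numbers stand for an effect only at larger amounts of compound and lower numbers for an effect already at smaller amounts), compound 1 `O=C(O)c1ccccc1-c1ccc(CCc2ncc(Cc3ccc(F)cc3)[nH]2)cc1` gives 1600 nM. Compound 2 `CC(C)CCc1cnc(CCc2ccc(-c3ccccc3C(=O)O)cc2)[nH]1` gives 119 nM in this assay, and compound 3 `CC(C)(C)c1cnc(CCc2ccc(-c3ccccc3C(=O)O)cc2)[nH]1` gives 4330 nM in this assay. Among the compounds with values here, compound 3 therefore stands at the highest number of the three measured so far: the nearest is compound 1, with a 2.7-fold higher number from compound 1 to compound 3 (0.43 log units; beyond the scatter), and the furthest is compound 2, with a 36-fold higher number from compound 2 to compound 3 (1.56 log units; beyond the scatter).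

The next step leads to compound 4 `CC(C)(C)CCc1cnc(CCc2ccc(-c3ccccc3C(=O)O)cc2)[nH]1`, which is 3,3-dimethylbutyl in place of tert-butyl on an aromatic carbon. Of the measured steps, the one that bears most directly on this change is a 36-fold higher number from compound 2 to compound 3 (1.56 log units; beyond the scatter), since compound 2 carries an isopentyl group at the same place and compound 4 returns to a chain of that kind, 3,3-dimethylbutyl, rather than the compact tert-butyl of compound 3. The step of a 13-fold lower number from compound 1 to compound 2 (1.13 log units; beyond the scatter) points the same way, in that a branched chain at this place gave the lowest number in the set. A large step down from compound 3 is therefore expected, of the order of a 22-fold lower number from compound 3 to compound 4 (1.34 log units; beyond the scatter), bringing compound 4 close to the number seen for compound 2, though not necessarily matching it.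

Compound 4 is estimated to give 200 nM in this assay, with an expected range from 60 nM to 700 nM.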

Compound 4, half-maximal effective concentration: 39 nM
Estimate against measurement, compound 4: 5.1-fold (0.71 log units) above, outside the stated range (below it).
By their numbers in this assay, from the lowest: compound 4; then compound 2; then compound 1; then compound 3.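

In this assay, the step of a 110-fold lower number from compound 3 to compound 4 (2.05 log units; beyond the scatter) shows that this place on the five-membered aromatic ring tolerates a bulky tert-butyl end much better when it is carried on a chain, as in 3,3-dimethylbutyl, than when it is bound directly to the aromatic carbon. The chain end also still matters: a 3.1-fold lower number from compound 2 to compound 4 (0.48 log units; beyond the scatter) is a modest step beyond the scatter for one added methyl, and a 41-fold lower number from compound 1 to compound 4 (1.61 log units; beyond the scatter) places the 3,3-dimethylbutyl chain well ahead of the 4-fluorobenzyl group of compound 1. Nothing available on these compounds accounts for the size of these steps.

On these data alone, how far this trend extends remains open: a longer chain such as 4,4-dimethylpentyl, or a cyclohexyl ring carried on the chain, could lower the number further or reverse the trend. Also open, as far as these compounds go, are the response to an amine or hydroxyl group on the chain, and the part played by the carboxylic acid, which is present unchanged in all four compounds.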